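Removing the pentyl chain from compound 2

The source may hold more compounds than are shown below. What is called first, only, known or untested is meant among the compounds shown, and "the series" means these compounds.

Compound 2 `CCCCCNc1nc(N)c2nc(O)n(Cc3ccccc3)c2n1` is the only one of the three measured compounds whose result is a number: in a functional assay (spleen, spleen) for activation, with Mus musculus as the target (on this read-out higher numbers stand for an effect only at larger amounts of compound and lower numbers for an effect already at smaller amounts), compound 2 gives 0.1 uM. Compound 1 `COc1nc2c(N)ncnc2n1Cc1ccccc1` reaches only a limit of the assay, and in this assay compound 1 gives > 10 uM. Compound 3 `Nc1ncnc2c1nc(Cl)n2Cc1ccccc1` also stops at a limit, as in this assay compound 3 gives > 10 uM. Among the measured compounds shown here, the one step between measured compounds, a step that the two limits leave unreadable from compound 1 to compound 3, therefore cannot be sized, because the limit of > 10 uM in this assay, at which 2 of the 3 values shown sit, holds both of its ends.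

Compound 4 `Nc1nc(N)c2nc(O)n(Cc3ccccc3)c2n1` differs from compound 2 in a single place: hydrogen in place of pentyl on a nitrogen on an aromatic ring. For the measured compounds named here, no measured step covers this change. Going by the values given here, the two limits show only that compound 1 and compound 3, which carry no second amino group on the shared core, sit where the assay stops, while compound 2 with its pentylamino group gives a clear number. Cutting the five-carbon chain back to a bare amino group is expected to move compound 4 toward larger amounts. The estimate for compound 4 in this assay is 3 uM, expected to fall between 0.5 uM and 10 uM. The step this estimate implies, a 30-fold higher number from compound 2 to compound 4 (1.48 log units; beyond the scatter), is expected to lie beyond the usual scatter.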

Compound 4, minimum effective concentration: 10 uM
Beside the measured number, compound 4's estimate is 3.3-fold (0.52 log units) below it; the range from low to high includes it.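

In this assay, among the compounds shown here, this is the first step that can be read at this position: replacing pentyl with hydrogen on a nitrogen on an aromatic ring gives a 100-fold higher number from compound 2 to compound 4 (2.00 log units; beyond the scatter). The pentylamino group of compound 2 therefore accounts for a large part of its effect at small amounts, yet removing the chain does not abolish the response, as compound 4 still returns a number, 10 uM. The earlier compounds shown here could not show this, as compound 1 and compound 3 are both limits of the assay and the step between them cannot be read: the limit of > 10 uM in this assay, at which 2 of the 4 values shown sit.

The compounds shown give only the two ends of this change, pentyl and hydrogen, so they leave open how the read-out moves with a shorter chain such as propyl, with a longer chain such as heptyl, or with a cyclic group such as cyclohexyl on the same nitrogen. They also leave open whether a branched chain such as isopentyl or an ether-containing chain such as methoxyethyl would keep the effect that pentyl gives in compound 2.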